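The source may hold more compounds than are shown below. What is called first, only, known or untested is meant among the compounds shown, and "the series" means these compounds.

Measured so far in a functional assay on KBVIN cells (Homo sapiens) for antiproliferative activity, read by sulforhodamine B assay, with a stated time of 3 days; on this read-out higher numbers stand for an effect only at larger amounts of compound and lower numbers for an effect already at smaller amounts:
- compound 1 `CCC1=C(O)c2c(oc(-c3ccc(CC)cc3)cc2=O)C(CC)(CC)C1=O`: 0.07 uM
- compound 2 `CCC1=C(O)c2c(oc(-c3cccc(OC)c3)cc2=O)C(CC)(CC)C1=O`: 1.22 uM
- compound 3 `CCC1=C(O)c2c(oc(-c3ccc(OC)c(OC)c3)cc2=O)C(CC)(CC)C1=O`: 1 uM

Compound 3 gives 1 uM, the second highest of the three numbers. It lies within the scatter of compound 2 at 1.22 uM, while compound 1 at 0.07 uM has a lower number, beyond the scatter.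

The next compound is compound 4 `CCC1=C(O)c2c(oc(-c3ccc(OC)c(Cl)c3)cc2=O)C(CC)(CC)C1=O`, with chloro in place of methoxy on an aromatic carbon, ortho to a methoxy group and meta to a large group: chloro in place of methoxy on an aromatic carbon.

Among the measured compounds shown here, no measured step makes this exact exchange, so the evidence is indirect. The nearest is a 1.2-fold lower number from compound 2 to compound 3 (0.09 log units; within the scatter), where methoxy in place of hydrogen on an aromatic carbon left the number within the scatter. The other is a 17-fold higher number from compound 1 to compound 2 (1.24 log units; beyond the scatter), with 3-methoxyphenyl in place of 4-ethylphenyl, which shows that a larger change on the aromatic group can move the number far. A single-substituent exchange therefore points to no step beyond the scatter in this assay, with a slight lean toward a lower number and a wide margin.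

The estimated step is a 1.7-fold lower number from compound 3 to compound 4 (0.22 log units; within the scatter). For compound 4 the expected value is 0.6 uM, with an estimated range from 0.15 uM to 2 uM.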

Compound 4, concentration for half-maximal effect: 1.37 uM
For compound 4 the middle estimate is 2.3-fold (0.36 log units) below the measured one; measured number inside the range.
By their numbers in this assay, from the lowest: compound 1; then compounds 3, 2 and 4 (each within the scatter of the next).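

In this assay, among the compounds shown here, chloro in place of methoxy on this aromatic carbon, ortho to a methoxy group and meta to a large group, gives a 1.4-fold higher number from compound 3 to compound 4 (0.14 log units; within the scatter), so at this position the series so far does not separate the two groups, although chloro brings one heavy atom and no hydrogen-bond acceptor where methoxy brought two heavy atoms and one acceptor. The comparison with the ring lacking any group at this carbon reads a 1.1-fold higher number from compound 2 to compound 4 (0.05 log units; within the scatter), which means that neither methoxy nor chloro here moves the number beyond the scatter, and the earlier result for methoxy alone now holds for a second group. The large gap remains on the other side of the series, at a 20-fold higher number from compound 1 to compound 4 (1.29 log units; beyond the scatter), so exchanging the group at this carbon has not brought a compound near compound 1, and the 4-ethylphenyl group remains the only aryl group shown with a number that low.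

Nothing available here explains these steps. Still open, on these data alone, are whether an amine, a carboxylic acid or a longer chain such as propyl at this carbon would move the number beyond the scatter, and how chloro would behave on a ring that also carries ethyl.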